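Removing the bromo group from the benzamide of compound 1

The source may hold more compounds than are shown below. What is called first, only, known or untested is meant among the compounds shown, and "the series" means these compounds.

compound 1 `COc1cc(/C=C/c2nnc(NC(=O)c3ccccc3Br)s2)c(Br)c(OC)c1OC`: 210 nM
compound 2 `COc1cccc(C(=O)Nc2nnc(/C=C/c3cc(OC)c(OC)c(OC)c3)s2)c1`: 150 nM
compound 3 `COc1ccc(/C=C/c2nnc(NC(=O)c3ccccc3OC)s2)cc1OC`: 170 nM

All three values come from a functional assay on A549 cells (Homo sapiens) for antiproliferative activity, read by MTT assay, with a stated time of 48 h; on this read-out lower numbers stand for stronger inhibition and higher numbers for weaker inhibition. On this read-out compound 1 sits within the scatter of both compound 2 and compound 3, so the three numbers show no order among themselves.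

The next compound to be measured is compound 4 `COc1cc(/C=C/c2nnc(NC(=O)c3ccccc3)s2)c(Br)c(OC)c1OC`. It differs from compound 1 in one place: hydrogen in place of bromo on an aromatic carbon. Hydrogen stands in place of bromo on an aromatic carbon, ortho to a large group, so 2-bromophenyl becomes phenyl. The rest of the core of compound 1 stays the same.

Within the data shown here, no measured pair isolates this change, so the expectation rests on the narrow spread of the values: compound 2 gives 150 nM and compound 3 gives 170 nM, both close to compound 1 despite differing from it in several places. In this assay, no step beyond the scatter is expected in either direction.

The expected step is a 1.1-fold lower number from compound 1 to compound 4 (0.04 log units; within the scatter).

For compound 4 the estimated value is 190 nM, with an expected range of 90 nM to 400 nM.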

Compound 4, half-maximal inhibitory concentration: 110 nM
Estimate against measurement, compound 4: 1.7-fold (0.24 log units) above; measured number inside the range.
By their numbers in this assay, from the lowest: compounds 4, 2, 3 and 1 (each within the scatter of the next).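

In this assay, among these compounds, the first pair of the series differing in one place gives a 1.9-fold lower number from compound 1 to compound 4 (0.28 log units; within the scatter) with hydrogen in place of bromo on an aromatic carbon, ortho to a large group. The 2-bromophenyl of compound 1 and the phenyl of compound 4 therefore cannot be told apart on this read-out, so this bromo group is not required for a number in the range seen across the series. No measurement here bears on why the step is this size.

An amine, a carboxylic acid or a methoxy group at this same place on compound 4 remains untested among the compounds shown, so the tolerance of this position is known only for bromo and hydrogen. As far as these compounds go, whether the step holds without the other bromo group of compound 4 also stays open.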